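The source may hold more compounds than are shown below. What is called first, only, known or untested is meant among the compounds shown, and "the series" means these compounds.

Compound 1 `CCCCC(C)(O)C/C=C/[C@H]1[C@H](O)CC(=O)[C@@H]1CC/C=C\CCC(=O)OC` gives 0.049 mg/kg in a functional assay on the whole organism with Rattus norvegicus as the target; on this read-out higher numbers stand for an effect only at larger amounts of compound and lower numbers for an effect already at smaller amounts. Compound 2 `COC(=O)CC/C=C\CC[C@H]1C(=O)C[C@@H](O)[C@@H]1/C=C/C[C@@](C)(O)/C=C/C1CCC1` gives 0.53 mg/kg. Compound 3 `COC(=O)CC/C=C\CC[C@H]1C(=O)C[C@@H](O)[C@@H]1/C=C/CC(C)(O)CCC1CCC1` gives 0.316 mg/kg.

Compound 1 has the lowest number of the three in this assay. Compound 4 `COC(=O)CC/C=C\CC[C@H]1C(=O)C[C@@H](O)[C@@H]1/C=C/C[C@@](C)(O)/C=C/C1(C)CC1` has not yet been measured; it differs from compound 1 in one place: 1-hydroxy-1-methyl-3-(1-methylcyclopropyl)prop-2-en-1-yl in place of 1-hydroxy-1-methylpentyl on a saturated chain carbon bound to a double-bonded chain carbon. The closest measured step is an 11-fold higher number from compound 1 to compound 2 (1.03 log units; beyond the scatter), where a 3-cyclobutyl-1-hydroxy-1-methylprop-2-en-1-yl group entered at the same place; the step of a 6.4-fold higher number from compound 1 to compound 3 (0.81 log units; beyond the scatter) also raised the number, and a 1.7-fold lower number from compound 2 to compound 3 (0.22 log units; within the scatter) stayed within the scatter. A rise of similar size is therefore expected here, giving an 8.2-fold higher number from compound 1 to compound 4 (0.91 log units; beyond the scatter). Compound 4 is estimated at 0.4 mg/kg, within 0.12 mg/kg to 1.3 mg/kg.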

Compound 4, dose for half-maximal effect: 1.34 mg/kg
Compound 4: middle estimate off by 3.4-fold (0.53 log units), on the low side; the measured number lies above the stated range.
By their numbers in this assay, from the lowest: compound 1; then compounds 3 and 2 (each within the scatter of the next); then compound 4.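

In this assay, the ring at the end of the side chain matters: 1-methylcyclopropyl in place of cyclobutyl gives a 2.5-fold higher number from compound 2 to compound 4 (0.40 log units; beyond the scatter), while the earlier double-bond change stayed within the scatter. For the compounds shown here, compound 4 now has the highest number of the four, with a 4.2-fold higher number from compound 3 to compound 4 (0.63 log units; beyond the scatter) and the largest step so far, a 27-fold higher number from compound 1 to compound 4 (1.44 log units; beyond the scatter). No measurement offered here explains these rises. The compounds shown leave open whether ring size or the added methyl drives the step, which a plain cyclopropyl group could help separate.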